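A few compounds are considered here, and "the series" means these few. Any claim that something is new, unique, unknown or untested is made for them only; others in the source may bear on it.

Compound 1 `CCCCCCCCCCCCCCNc1nc(=O)c2ncn([C@@H]3O[C@H](CO)[C@@H](O)[C@H]3O)c2c(=O)[nH]1` — 30 ug/mL
Compound 2 `O=c1nc(Nc2ccccc2)[nH]c(=O)c2c1ncn2C1O[C@H](CO)[C@@H](O)[C@H]1O` — > 500 ug/mL (a limit of the assay)

Among the compounds with values here, in an assay on isolated protein for inhibition of ATP-dependent RNA helicase SUPV3L1, mitochondrial (Homo sapiens) (on this read-out lower numbers stand for stronger inhibition and higher numbers for weaker inhibition), compound 1 gives 30 ug/mL, the only numerical value obtained so far. Compound 2 sits at the limit of > 500 ug/mL in this assay, at which 1 of the 2 values shown sits, so it offers no number to compare against. Within the data shown here, no step between two measured compounds is available, and what follows rests on the structural change alone.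

Compound 3 `CCCCCCCCCCCCNc1nc(=O)c2ncn([C@@H]3O[C@H](CO)[C@@H](O)[C@H]3O)c2c(=O)[nH]1` differs from compound 1 by hydrogen in place of ethyl on a saturated chain carbon, ten or more bonds along the chain from a nitrogen on an aromatic ring. Among the measured compounds shown here, no measured pair frames this change, so any size of step for it is uncertain. The expectation is for no change beyond the usual scatter in this assay, with at most a slight weakening, and compound 3 is expected to show a step of a 1.3-fold higher number from compound 1 to compound 3 (0.12 log units; within the scatter). Compound 3 is therefore estimated at 40 ug/mL, with a likely range from 15 ug/mL to 120 ug/mL.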

Compound 3, half-maximal inhibitory concentration: 150 ug/mL
Estimate against measurement, compound 3: 3.8-fold (0.57 log units) below; the whole stated range lies below it.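

Within the data shown here, the first measured step on this chain is a 5.0-fold higher number from compound 1 to compound 3 (0.70 log units; beyond the scatter) in this assay, and it comes from hydrogen in place of ethyl on a saturated chain carbon, ten or more bonds along the chain from a nitrogen on an aromatic ring. The far end of the chain is therefore not a silent part of these compounds, since the read-out responds to a change made this far out. Within this pair, the compound with the longer chain gives the lower number.

Two chain lengths cannot show whether a longer chain would lower the number further, or whether an amine or a carboxylic acid at the chain end would be accepted. Compound 2 offers no number for comparison, only a limit of the assay: the limit of > 500 ug/mL in this assay, at which 1 of the 3 values shown sits.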